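Methylsulfanyl for Carbamoyl: Expected Cytotoxicity of Compound 3

The compounds below may be only part of what the source reports. "The series", "measured", "known", "first", "only" and "open" are said of these compounds alone.

Compound 2 `Cc1ccc2[nH]c(=O)c(CN(Cc3ccc(C(N)=O)cc3)Cc3ccc(C(C)(C)C)cc3)cc2c1` stands at a limit in a toxicity assay on MDCK cells (Canis lupus familiaris) for cytotoxicity, read by crystal violet staining, with a stated time of 48 h; on this read-out higher numbers stand for lower toxicity in this test and lower numbers for higher toxicity in this test: compound 2 gives > 5000 nM, a limit of the assay and not a number. Compound 1 `COc1ccc(CN(Cc2ccc(C(C)(C)C)cc2)Cc2cc3cc(C)ccc3[nH]c2=O)cc1` likewise gives only a limit, > 10000 nM, in this assay. The step that the two limits leave unreadable from compound 1 to compound 2 is therefore of unreadable size. Compound 3 `CSc1ccc(CN(Cc2ccc(C(C)(C)C)cc2)Cc2cc3cc(C)ccc3[nH]c2=O)cc1` carries methylsulfanyl in place of carbamoyl on an aromatic carbon. For the measured compounds named here, since no measured step reads as a number, no step beyond the scatter is expected in this assay. The estimated step that the limit leaves unreadable from compound 2 to compound 3 from compound 2 to compound 3 is expected to be small. Compound 3 is expected to give 10000 nM, within 3000 nM to 30000 nM, most likely again only as a limit.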

Compound 3, half-maximal cytotoxic concentration: > 5000 nM
Compound 3 ended at the assay's limit; the forecaster's own chance of this, stated with the estimate: 80%; the middle value is on the limit's open side.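

In this assay, for the compounds shown here, compound 1, compound 2 and compound 3 all stand at limits of the assay, so no step among them can be read. The compounds shown leave open whether exchanging carbamoyl, methoxy and methylsulfanyl changes the half-maximal cytotoxic concentration at all.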